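The source may report more compounds than this note shows. Statements on the series, on what has been measured and on what is new or still open speak of the compounds shown alone.

Series notes, ring on the sulfonyl sulfur.

In a functional assay on the whole organism (strain Jcl:SD) for inhibition, with Rattus norvegicus as the target, with stated times of 3 min and 3 h, at a dose of 1 mg/kg by the intravenous route; a lower number here means less inhibition, a higher number more inhibition at the dose given (going by the name of the read-out): compound 1 `CNCc1cc(-c2cccnc2F)n(S(=O)(=O)c2cccc(C#N)c2)c1` gives 99%; compound 2 `CNCc1cc(-c2cccnc2F)n(S(=O)(=O)c2ccsc2)c1` gives 98%; compound 3 `CNCc1cc(-c2cccnc2F)n(S(=O)(=O)c2ccoc2)c1` gives 82%.

Compound 3 holds the lowest of the three numbers in this assay. The steps of a number 17 percentage points lower from compound 1 to compound 3 (beyond the scatter) and a number 16 percentage points lower from compound 2 to compound 3 (beyond the scatter) are both beyond the scatter, while a number 1 percentage points lower from compound 1 to compound 2 (within the scatter) lies within it, so the six-membered aromatic ring and thiophen-3-yl cannot be told apart here and only furan-3-yl falls off.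

Compound 4 `CNCc1cc(-c2cccnc2F)n(S(=O)(=O)c2cccnc2)c1` differs from compound 3 by pyridin-3-yl in place of furan-3-yl on a sulfonyl sulfur. Both measured steps that bear on it leave furan-3-yl as the weaker partner, so the move away from it is expected to recover a modest amount rather than lose more, with the ceiling of the read-out close above. Compound 4 is therefore estimated at 95%, within 82% to 100%, an expected step of a number 13 percentage points higher from compound 3 to compound 4 (beyond the scatter).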

Compound 4, a percentage reported as inhibition, in the whole organism at one dose (the size of the read-out at that dose, not a potency): 96%
For compound 4 the middle estimate is 1 percentage points below the measured one; low and high end bracket the measured number.
By their numbers in this assay, from the lowest: compound 3; then compounds 4, 2 and 1 (each within the scatter of the next).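

In this assay the change to pyridin-3-yl on a sulfonyl sulfur gives a number 14 percentage points higher from compound 3 to compound 4 (beyond the scatter) and shows that a single hetero atom in the ring does not by itself bring the shortfall seen with furan-3-yl. With a number 2 percentage points lower from compound 2 to compound 4 (within the scatter) and a number 3 percentage points lower from compound 1 to compound 4 (within the scatter) as well, pyridin-3-yl cannot be told apart from thiophen-3-yl or 3-cyanophenyl, leaving furan-3-yl alone in falling off among these four rings. Nothing available here accounts for the furan-3-yl result.

From the compounds shown here alone, whether a saturated ring such as piperidine, or a phenyl ring bearing an amine or a carboxylic acid, would hold up on this sulfur remains open. At this single dose, compound 1, compound 2 and compound 4 also stay unresolved from one another.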